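Swapping Methoxy for Amino on the Pyridine Arm

This account rests on a few compounds, and the source may have more. Where it says the series, first, only, none or still open, it means among the compounds named here.

Compound 1, `COc1cccc(Cn2cnc3sc(-c4ccnc(C)c4)cc3c2=O)c1`: 2520 nM
Compound 2, `COc1cccc(Cn2cnc3sc(-c4ccnc(OC)c4)cc3c2=O)c1`: > 10000 nM

Both compounds were tested in an assay on isolated protein for inhibition of Rho-associated protein kinase 1 (Homo sapiens), read by radiometric assay and 33P incorporation, with a stated time of 40 min, in the presence of a further agent that is not named here; a higher number here means a weaker inhibitor, a lower number a stronger inhibitor. Compound 1 gives 2520 nM. The value of compound 2 is a limit of the assay rather than a number: the limit of > 10000 nM in this assay, at which 1 of the 2 values shown sits. So the step of an at least 3.9-fold higher number from compound 1 to compound 2 (0.59 log units; beyond the scatter), and compound 2 stands at the weak end of the two values shown.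

Compound 3, `COc1cccc(Cn2cnc3sc(-c4ccnc(N)c4)cc3c2=O)c1`, has not yet been measured. It differs from compound 2 by amino in place of methoxy on an aromatic carbon. Among the measured compounds shown here, only one measured step bears on this change, the one from compound 1 to compound 2, and it runs the other way, from methyl to methoxy; nothing measured here tells what an amino group at the same place does. Because compound 2 sits at the limit of > 10000 nM in this assay, at which 1 of the 2 values shown sits, the size of any step to compound 3 is open. The estimate for compound 3 in this assay is 4000 nM, within 800 nM to 20000 nM, which means an expected step of an at least 2.5-fold lower number from compound 2 to compound 3 (0.39 log units; beyond the scatter).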

Compound 3, half-maximal inhibitory concentration: 18 nM
For compound 3 the middle estimate is 220-fold (2.35 log units) above the measured one; the measured number lies below the stated range.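

In this assay, this position on the pyridine arm turns out to matter far more than the first two compounds could show: amino in place of methoxy gives an at least 550-fold lower number from compound 2 to compound 3 (2.74 log units; beyond the scatter), and amino in place of methyl gives a 140-fold lower number from compound 1 to compound 3 (2.15 log units; beyond the scatter). The gain therefore belongs to amino itself and does not come merely from removing methoxy, since compound 1, with methyl at this place, remains much weaker. The value of compound 2 is a limit of the assay and not a number, so the true size of its step remains unknown: the limit of > 10000 nM in this assay, at which 1 of the 3 values shown sits.

Amino brings a hydrogen-bond donor that methoxy lacks, but these compounds cannot show whether that difference accounts for the result. As far as these compounds go, a methylamino or dimethylamino group at the same place could test this, and whether the gain holds with other groups elsewhere on the shared core remains open.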